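Halogen and Side-Chain Swaps in a Vero Cytotoxicity Series

The source may report more compounds than this note shows. Statements on the series, on what has been measured and on what is new or still open speak of the compounds shown alone.

Compound 1 `C#CCNc1nc(SC)nc(CCO)c1Cl`: 485000 nM
Compound 2 `C=CCNc1nc(SC)nc(CCO)c1Cl`: 481000 nM
Compound 3 `C#CCNc1nc(SC)nc(CCO)c1Br`: 827000 nM

Of the compounds shown here, three of this small set have been measured in an ADME assay on Vero cells (Chlorocebus sabaeus) for cytotoxicity, with a stated time of 48 h; a lower number here means that less compound is tolerated, a higher number that more compound is tolerated. Compound 1 gives 485000 nM. Compound 2 differs from compound 1 by vinyl in place of ethynyl on a saturated chain carbon bound to a nitrogen on an aromatic ring; compound 2 gives 481000 nM, so the step is a 1.0-fold lower number from compound 1 to compound 2 (0.00 log units; within the scatter). Compound 3 differs from compound 1 in the core by bromo in place of chloro on an aromatic carbon; compound 3 gives 827000 nM, and the step is a 1.7-fold higher number from compound 1 to compound 3 (0.23 log units; within the scatter). All three numbers therefore sit close together, and none of the compounds can be called more or less tolerated than another on this evidence.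

Compound 4 `C=CCNc1nc(SC)nc(CCO)c1Br` has not yet been measured in this assay. It differs from compound 3 by vinyl in place of ethynyl on a saturated chain carbon bound to a nitrogen on an aromatic ring, which is the same change already seen from compound 1 to compound 2, at the same place in each pair; the only difference between the two pairs is the core change described above. The expected step from compound 3 to compound 4 is a 1.0-fold lower number from compound 3 to compound 4 (0.01 log units; within the scatter), placed beside the earlier step of a 1.0-fold lower number from compound 1 to compound 2 (0.00 log units; within the scatter), which was flat. For compound 4 the estimated half-maximal cytotoxic concentration is 800000 nM, expected to fall between 450000 nM and 1500000 nM, resting on the value of compound 3 827000 nM and the flat step from compound 1 to compound 2.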

Compound 4, half-maximal cytotoxic concentration: 411000 nM
Compound 4: the middle estimate sits 1.9-fold (0.29 log units) above what was measured, and the stated range ends above it.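

Carried to the bromo compounds in this assay, vinyl in place of ethynyl gives a 2.0-fold lower number from compound 3 to compound 4 (0.30 log units; within the scatter), and this does not differ from the same change on the chloro compounds: the same change on two cores in this assay, a 1.0-fold lower number (0.00 log units; within the scatter) from compound 1 to compound 2 and a 2.0-fold lower number (0.30 log units; within the scatter) from compound 3 to compound 4, 2.0-fold (0.30 log units) apart, within the scatter of two such steps

Read the other way, bromo in place of chloro on the vinyl compounds gives a 1.2-fold lower number from compound 2 to compound 4 (0.07 log units; within the scatter), and this agrees with the same change on the ethynyl compounds: the same change on two cores in this assay, a 1.7-fold higher number (0.23 log units; within the scatter) from compound 1 to compound 3 and a 1.2-fold lower number (0.07 log units; within the scatter) from compound 2 to compound 4, 2.0-fold (0.30 log units) apart, within the scatter of two such steps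

Within these four compounds, then, neither change behaves differently on one core than on the other, but every step lies within the scatter, so the comparison shows no measurable effect of either change and does not establish that the steps are truly equal or that they would carry to any other core.

The compounds shown leave open whether any change at these places can move the number beyond the scatter, for instance a saturated propyl chain in place of the propargyl or allyl group, or a fluoro or nitrile group in place of the halogen. From the compounds shown here alone, all four compounds also share the methylthio and hydroxyethyl groups, so it remains open how a compound would read with an amine or a carboxylic acid at either of those places.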